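A few compounds are considered here, and "the series" means these few. Any claim that something is new, unique, unknown or untested is made for them only; others in the source may bear on it.

Of the compounds shown here, two sharing one core have been measured so far in an in vivo ADME assay on the whole organism for pharmacokinetics, with Rattus norvegicus as the target; a higher number here means that more of the compound sits outside the plasma, a lower number that more of the compound stays in the plasma. Compound 1 (`CC1(C)C=C(c2cc(-c3ccc(F)cc3Cl)c3ccc(=O)n(-c4c(Cl)cccc4Cl)c3c2)CC(C)(C)N1`) gives 7.32 L/kg and compound 2 (`CC(C)(C)N1CCC(c2cc(-c3ccc(F)cc3Cl)c3ccc(=O)n(-c4c(Cl)cccc4Cl)c3c2)CC1`) gives 3.84 L/kg. The move between them is a 1.9-fold lower number from compound 1 to compound 2 (0.28 log units; within the scatter), so compound 2 cannot be separated from compound 1 on these numbers.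

The next step leads to compound 3 (`CC(C)(C)N1CCC(c2cc(-c3ccc(F)cc3F)c3ccc(=O)n(-c4c(Cl)cccc4Cl)c3c2)CC1`), with the change (fluoro in place of chloro on an aromatic carbon). This puts fluoro in place of chloro on an aromatic carbon, ortho to a large group, turning 2-chloro-4-fluorophenyl into 2,4-difluorophenyl.

Within the data shown here, no measured step covers this exchange. The only one available, a 1.9-fold lower number from compound 1 to compound 2 (0.28 log units; within the scatter), swaps a different group elsewhere on the core, so it offers no direct guide to the size or direction of the present change. With nothing to point either way, no shift beyond the scatter is expected in this assay, and the expectation stays anchored on compound 2 at 3.84 L/kg.

The estimated change is a 1.1-fold lower number from compound 2 to compound 3 (0.05 log units; within the scatter). For compound 3 the expected value is 3.4 L/kg, with an estimated range of 1.8 L/kg to 6.5 L/kg.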

Compound 3, volume of distribution at steady state: 3.82 L/kg
Beside the measured number, compound 3's estimate is 1.1-fold (0.05 log units) below it; low and high end bracket the measured number.
By their numbers in this assay, from the lowest: compounds 3, 2 and 1 (each within the scatter of the next).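

In this assay, among these compounds, fluoro in place of chloro on an aromatic carbon, ortho to a large group, comes out as a 1.0-fold lower number from compound 2 to compound 3 (0.00 log units; within the scatter), the first reading for a change at this position. Among the compounds shown here, the one earlier step altered a different group on the shared core, whereas this one shows that 2-chloro-4-fluorophenyl and 2,4-difluorophenyl cannot be separated on the volume of distribution at steady state when the rest of compound 2 is kept, so the chloro is not required at this position to hold the number where it stands. Nothing available here speaks to why the two halogens read alike.

As far as these compounds go, this rests on a single pair of halogens, so it remains open whether a methyl, methoxy or nitrile group at the same position would also stay within the scatter, or whether a larger group such as trifluoromethyl would move the number beyond it. For the compounds shown here, it is also open whether the same exchange would read alike with the group carried by compound 1 in place of the one carried by compound 2.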